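This account rests on a few compounds, and the source may have more. Where it says the series, first, only, none or still open, it means among the compounds named here.

In a functional assay on MCF7 cells (Homo sapiens) for inhibition, read by sulforhodamine B assay (on this read-out higher numbers stand for weaker inhibition and lower numbers for stronger inhibition), compound 1 `O=C1C=C(N2CCC2)C(=O)c2c1nc1n2[C@H]2OC[C@@H](O)[C@H]2OC1` gives > 16000 nM, which is a limit and not a number. Compound 2 `O=C1C=C(NC2CCCC2)C(=O)c2c1nc1n2[C@H]2OC[C@@H](O)[C@H]2OC1` gives > 16000 nM, also a limit. Between these two lies a step that the two limits leave unreadable from compound 1 to compound 2. Among the measured compounds shown here, compound 3 `CCOc1ccc(NC2=CC(=O)c3nc4n(c3C2=O)[C@H]2OC[C@@H](O)[C@H]2OC4)cc1`, at 1430 nM, holds the only number in the set, reached by an at least 11-fold lower number from compound 2 to compound 3 (1.04 log units; beyond the scatter). Compound 4 `O=C1C=C(Nc2ccc(I)cc2)C(=O)c2c1nc1n2[C@H]2OC[C@@H](O)[C@H]2OC1` keeps the phenyl on the amine nitrogen and differs from compound 3 by iodo in place of ethoxy on an aromatic carbon. For the measured compounds named here, no measured step covers this exchange, so the only guide is that large step to compound 3 , and the phenyl behind it stays. No step beyond the scatter is expected in this assay, and no direction is favoured. The expected change is a 1.0-fold lower number from compound 3 to compound 4 (0.01 log units; within the scatter). For compound 4 the estimated value is 1400 nM, with an expected range from 450 nM to 5000 nM.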

Compound 4, half-maximal inhibitory concentration: 2230 nM
Compound 4: the middle estimate sits 1.6-fold (0.20 log units) below what was measured; low and high end bracket the measured number.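

In this assay, iodo in place of ethoxy on the aromatic carbon gives a 1.6-fold higher number from compound 3 to compound 4 (0.19 log units; within the scatter), so the oxygen of ethoxy is not needed to keep a measurable number here. With a second group at this place, the phenyl on the amine nitrogen again stands apart from the two compounds without it, with an at least 7.1-fold lower number from compound 2 to compound 4 (0.85 log units; beyond the scatter) and an at least 7.1-fold lower number from compound 1 to compound 4 (0.85 log units; beyond the scatter). Both of these steps start from a limit and not a number: the limit of > 16000 nM in this assay, at which 2 of the 4 values shown sit.

The compounds shown leave open whether a carboxylic acid, an amine or a longer alkoxy chain at this place would hold the number in the same range. They also leave open what the phenyl gives with only hydrogen there.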